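The source may report more compounds than this note shows. Statements on the series, on what has been measured and on what is new or still open speak of the compounds shown alone.

Measured compounds:
Compound 1, `Cc1cc(Cl)cc(-c2ccnc3cc(CN4C(=O)C5CC5C4=O)sc23)c1O[C@@H]1CCNC[C@@H]1C` — in an assay on isolated protein for inhibition of ubiquitin carboxyl-terminal hydrolase 7 (Homo sapiens), read by fluorescence, with stated times of 30 min and 1 h (on this read-out lower numbers stand for stronger inhibition and higher numbers for weaker inhibition), compound 1 gives 1.1 nM.
Compound 2, `Cc1cc(Cl)cc(-c2ccnc3cc(CN4C(=O)C5C(C4=O)C5(C)C)sc23)c1C[C@@H]1CNCCO1` — in this assay compound 2 gives 0.44 nM.
Compound 3, `Cc1cc(Cl)cc(-c2ccnc3cc(CN4C(=O)CCC4=O)sc23)c1O[C@@H]1CCNC[C@@H]1C` — in this assay compound 3 gives 2.1 nM.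

Compound 3 stands at the highest of the three numbers; compound 1 is nearest, within the scatter, and compound 2 is furthest, beyond it.

The next compound is compound 4, `Cc1cc(Cl)cc(-c2ccnc3cc(CN4C(=O)C5C(C4=O)C5(C)C)sc23)c1O[C@@H]1CCNC[C@@H]1C`. Relative to compound 3 the change is a group of 10 heavy atoms (7 carbon, 1 nitrogen, 2 oxygen; one three-membered non-aromatic ring of carbon only, one five-membered non-aromatic ring with 1 hetero atom) in place of a group of 7 heavy atoms (4 carbon, 1 nitrogen, 2 oxygen; one five-membered non-aromatic ring with 1 hetero atom), on a saturated chain carbon bound to an aromatic carbon. For the measured compounds named here, one measured step bears on it directly: a 1.9-fold higher number from compound 1 to compound 3 (0.28 log units; within the scatter), a within-scatter shift on exchanging a related cyclopropane-fused imide for the 2,5-dioxopyrrolidin-1-yl group. Compound 2 carries the same entering group as compound 4 but differs elsewhere, so its value is only a loose pointer; it does sit at the low end of the set.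

Reversing a shift of that size is expected to give a 2.6-fold lower number from compound 3 to compound 4 (0.42 log units; beyond the scatter), a step towards a lower number. Compound 4 is therefore estimated at 0.8 nM, within 0.3 nM to 2 nM.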

Compound 4, half-maximal inhibitory concentration: 0.18 nM
Beside the measured number, compound 4's estimate is 4.4-fold (0.65 log units) above it, outside the stated range (below it).
By their numbers in this assay, from the lowest: compound 4; then compound 2; then compounds 1 and 3 (each within the scatter of the next).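

On the saturated chain carbon bound to an aromatic carbon, the earlier exchange stayed within the scatter in this assay (a 1.9-fold higher number from compound 1 to compound 3 (0.28 log units; within the scatter)), whereas the group of 10 heavy atoms gives both a 12-fold lower number from compound 3 to compound 4 (1.07 log units; beyond the scatter) and a 6.1-fold lower number from compound 1 to compound 4 (0.79 log units; beyond the scatter), so this position tolerates more than a flat response. With that group held constant, (3-methylpiperidin-4-yl)oxy in place of (morpholin-2-yl)methyl on an aromatic carbon gives a 2.4-fold lower number from compound 2 to compound 4 (0.39 log units; beyond the scatter), a smaller step that still lies beyond the scatter and leaves compound 4 the strongest inhibitor of the four. No evidence on the origin of either step is available.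

The compounds shown leave open whether the low number at this position survives with a simple amide, an amine or a carboxylic acid in place of the imide. As far as these compounds go, it also remains open whether the (morpholin-2-yl)methyl series responds to the 2,5-dioxopyrrolidin-1-yl group to the same extent.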